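Chlorophenyl Amide Series: Shifting the Chlorine

This account rests on a few compounds, and the source may have more. Where it says the series, first, only, none or still open, it means among the compounds named here.

Among the measured compounds shown here, compound 2 `O=C(CN(C(=O)c1cccc(Cl)c1)C1CCCCC1)Nc1cc(F)cc(F)c1` gives 1580 nM in an assay on HEK293 cells for inhibition of sodium- and chloride-dependent glycine transporter 1 (Homo sapiens), read by scintillation proximity assay (on this read-out lower numbers stand for stronger inhibition and higher numbers for weaker inhibition), and is the only member of the series with a number rather than a limit. Compound 1 `Cn1ccc(C(=O)N(CC(=O)Nc2cc(F)cc(F)c2)C2CCCCC2)n1` gives in this assay only a limit, > 25100 nM. For the measured compounds named here, the one measured step, an at least 15-fold lower number from compound 1 to compound 2 (1.20 log units; beyond the scatter), shows that the group on this carbonyl carbon sets the read-out strongly; because of the limit of > 25100 nM in this assay, at which 1 of the 2 values shown sits, its full size is not known. Compound 3 `O=C(CN(C(=O)c1ccccc1Cl)C1CCCCC1)Nc1cc(F)cc(F)c1` differs from compound 2 by 2-chlorophenyl in place of 3-chlorophenyl on a carbonyl carbon. Going by the values given here, no measured step compares two chlorophenyl groups that differ only in where the chlorine sits, so the measured step bears on the present one only in showing that the carbonyl substituent matters. A moderate loss with wide uncertainty is expected; the step is estimated at a 2.0-fold higher number from compound 2 to compound 3 (0.31 log units; beyond the scatter). Compound 3 is expected to give about 3200 nM in this assay, between 800 nM and 13000 nM.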

Compound 3, half-maximal inhibitory concentration in the sodium- and chloride-dependent glycine transporter 1 assay: 20000 nM
Beside the measured number, compound 3's estimate is 6.3-fold (0.80 log units) below it; the whole stated range lies below it.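

In the sodium- and chloride-dependent glycine transporter 1 assay compound 2 gives 1580 nM and compound 3 gives 20000 nM. In the sodium- and chloride-dependent glycine transporter 1 assay, changing only where the chlorine sits carries a large step, a 13-fold higher number from compound 2 to compound 3 (1.10 log units; beyond the scatter). Yet 3-chlorophenyl and 2-chlorophenyl have the same heavy atoms and the same count of hydrogen-bond donors and acceptors. The earlier step tied the read-out to the group on this carbonyl carbon; this one shows that having a chlorophenyl group there does not settle the read-out, which also depends on where the chlorine sits. In the sodium- and chloride-dependent glycine transporter 1 assay the comparison with compound 1 gives only a floor, an at least 1.2-fold lower number from compound 1 to compound 3 (0.09 log units; that floor lies within the scatter). The full size of that step cannot be read, because compound 1 carries a limit and not a number: the limit of > 25100 nM in the sodium- and chloride-dependent glycine transporter 1 assay, at which 1 of the 3 values shown sits.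

In a physicochemical assay for lipophilicity (on this read-out lower numbers stand for lower lipophilicity and higher numbers for higher lipophilicity), compound 2 is recorded as "not determined" (no result reported) and compound 3 as "not determined" (no result reported), so this read-out offers no comparison of the two.

What lies behind the difference between the two chlorophenyl groups remains open. Also open, on these data alone, is whether a bromine atom or a methoxy group in place of the chlorine of compound 2 would keep its read-out.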